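The source may hold more compounds than are shown below. What is called first, only, known or untested is meant among the compounds shown, and "the series" means these compounds.

Compound 1 `O=S(=O)(NCCN1CCCC1)c1cccc(-c2ccc3nccc(-c4ccnc(C(F)(F)F)c4)c3n2)c1`: 145000 nM
Compound 2 `O=S(=O)(CCO)c1cccc(-c2ccc3nccc(-c4ccncc4)c3n2)c1`: 55000 nM
Compound 3 `NS(=O)(=O)c1cccc(-c2ccc3nccc(N4CCN(Cc5ccccc5)CC4)c3n2)c1`: < 5000 nM

These three results come from a physicochemical assay for solubility, read by HPLC, using the shake flask method, measured as kinetic solubility, with a stated time of 20 h, at pH 6.5, tested at 200 uM; a lower number here means a less soluble compound, a higher number a more soluble compound. The entry for compound 3 < 5000 nM is a limit of the assay and not a number. That leaves two true numbers to compare. Compound 2, at 55000 nM, holds the lower of them, and compound 1, at 145000 nM, stands higher by more than the usual scatter of repeated measurements.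

The next compound to be tested is compound 4 `C[C@@H]1CN(S(=O)(=O)c2cccc(-c3ccc4nccc(-c5ccncc5)c4n3)c2)C[C@H](C)N1`. It keeps the shared core of compound 2 and changes in one place, with 3,5-dimethylpiperazin-1-yl in place of 2-hydroxyethyl on a sulfonyl sulfur. The incoming group brings a six-membered non-aromatic ring and 2 defined stereocentres.

For the measured compounds named here, no measured pair shows this change on its own, so the expectation is a loose one. It starts from compound 2 at 55000 nM, the closest relative, and allows for compound 1 at 145000 nM on the high side. The limit seen for compound 3 keeps the low side open. The expected outcome in this assay is a slight rise that stays within the scatter, and the estimated move is a 1.3-fold higher number from compound 2 to compound 4 (0.10 log units; within the scatter). For compound 4 the expected value is 70000 nM, with an estimated range of 20000 nM to 180000 nM.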

Compound 4, solubility: 180000 nM
Estimate against measurement, compound 4: 2.6-fold (0.41 log units) below; the measured number falls inside the stated range.
By their numbers in this assay, from the lowest: compound 2; then compounds 1 and 4 (each within the scatter of the next). At a limit, below all of these: compound 3.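

In this assay, for the compounds shown here, this is the first step that changes only the group on the sulfonyl sulfur while the rest of compound 2 stays the same: 3,5-dimethylpiperazin-1-yl in place of 2-hydroxyethyl gives a 3.3-fold higher number from compound 2 to compound 4 (0.51 log units; beyond the scatter). The counted differences are specific: the entering group has 8 heavy atoms where the leaving group has 3, and it adds a six-membered non-aromatic ring with 2 hetero atoms and 2 defined stereocentres, while the counts of hydrogen-bond donors and acceptors and the net charge stay the same. So at this place a larger ring-bearing group goes with a higher number, though this is one step only, and no measurement shown bears on which feature of the new group lies behind it.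

The compounds shown leave open whether the higher number belongs to the piperazine ring itself or to its two methyl groups, a question that plain piperazin-1-yl at the same sulfur would address. They also leave open how morpholin-4-yl, a different ring with an oxygen atom, or a longer chain ending in a carboxylic acid would read at this place.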